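Bromo for Chloro on the Anilino Ring of Compound 1

This account rests on a few compounds, and the source may have more. Where it says the series, first, only, none or still open, it means among the compounds named here.

Compound 1 `Clc1cccc(Nc2ncnc3ccc(NCc4ccc5c(c4)OCCCO5)cc23)c1` holds the lower of the two numbers recorded in a functional assay on A-431 cells (Homo sapiens) for antiproliferative activity, read by WST assay, with a stated time of 48 h; on this read-out higher numbers stand for weaker inhibition and lower numbers for stronger inhibition: in this assay compound 1 gives 2.59 ug/mL, while compound 2 `O=C(Nc1ccc2ncnc(Nc3cccc(Cl)c3)c2c1)C1COc2ccccc2O1` gives 19.9 ug/mL, a gap beyond the usual scatter. Compound 3 `Brc1cccc(Nc2ncnc3ccc(NCc4ccc5c(c4)OCCCO5)cc23)c1` differs from compound 1 by bromo in place of chloro on an aromatic carbon. Going by the values given here, no measured pair shows this exchange, so the expected step of a 1.2-fold lower number from compound 1 to compound 3 (0.07 log units; within the scatter) is small and not beyond the scatter in either direction. Compound 3 is accordingly estimated at 2.2 ug/mL, with a range from 0.9 ug/mL to 5.5 ug/mL.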

Compound 3, half-maximal inhibitory concentration: 2.77 ug/mL
Compound 3: middle estimate off by 1.3-fold (0.10 log units), on the low side; measured number inside the range.
By their numbers in this assay, from the lowest: compounds 1 and 3 (each within the scatter of the next); then compound 2.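

Going by these compounds alone, compound 3 provides the first measured exchange at this place on the aromatic ring. In this assay, going from 3-chlorophenyl to 3-bromophenyl gives a 1.1-fold higher number from compound 1 to compound 3 (0.03 log units; within the scatter), so this assay does not separate chloro from bromo on the core of compound 1. No available evidence bears on this result.

The compounds shown carry only chloro or bromo at this place, leaving open how a nitrile, a methoxy group or an amine would read there. Also open, on these data alone, is whether the same exchange would read alike on compound 2.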